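Extending the hydroxycarbamoyl chain beyond compound 2

The source may report more compounds than this note shows. Statements on the series, on what has been measured and on what is new or still open speak of the compounds shown alone.

Measured so far in a functional assay on PC-3 cells (Homo sapiens) for inhibition, read by MTT assay, with a stated time of 48 h; a lower number here means a stronger inhibitor, a higher number a weaker inhibitor:
- compound 1 `O=C(CCCCOC(=O)c1ccc2c(c1)no[n+]2[O-])NO`: 12700 nM
- compound 2 `O=C(CCCCCCOC(=O)c1ccc2c(c1)no[n+]2[O-])NO`: 950 nM

Of these two, compound 2 holds the lower number, 950 nM, and is the stronger inhibitor. Among the measured compounds shown here, the single measured step, a 13-fold lower number from compound 1 to compound 2 (1.13 log units; beyond the scatter), is large and lies beyond the scatter. It put 2-(hydroxycarbamoyl)ethyl in place of hydroxycarbamoyl on a saturated chain carbon.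

Compound 3 `O=C(CCCCCCCOC(=O)c1ccc2c(c1)no[n+]2[O-])NO` has not yet been measured. Its difference from compound 2 is (hydroxycarbamoyl)methyl in place of hydroxycarbamoyl on a saturated chain carbon, six bonds along the chain from an oxygen next to a carbonyl group. Cut one bond further out, the same difference reads 3-(hydroxycarbamoyl)propyl to 4-(hydroxycarbamoyl)butyl.

For the measured compounds named here, only one step bears on this change in this assay, and two compounds cannot show whether the trend continues or levels off. Going by the values given here, with a 13-fold lower number from compound 1 to compound 2 (1.13 log units; beyond the scatter) as the sole guide, a much smaller step in the same direction is expected for this shorter extension. The expected step is a 1.7-fold lower number from compound 2 to compound 3 (0.24 log units; within the scatter), which may well stay within the scatter. For compound 3 the estimated value is 550 nM, with an expected range of 200 nM to 1600 nM.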

Compound 3, half-maximal inhibitory concentration: 1390 nM
The estimate for compound 3 lay 2.5-fold (0.40 log units) below the measured number, and the stated range covers the measured number.
By their numbers in this assay, from the lowest: compounds 2 and 3 (each within the scatter of the next); then compound 1.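

In this assay the further extension, (hydroxycarbamoyl)methyl in place of hydroxycarbamoyl on a saturated chain carbon, six bonds along the chain from an oxygen next to a carbonyl group, gave a 1.5-fold higher number from compound 2 to compound 3 (0.17 log units; within the scatter) and so did not separate compound 3 from compound 2. The advantage over the shorter chain of compound 1 is nevertheless retained, with 3-(hydroxycarbamoyl)propyl in place of hydroxycarbamoyl, four bonds along the chain from an oxygen next to a carbonyl group, giving a 9.1-fold lower number from compound 1 to compound 3 (0.96 log units; beyond the scatter) and showing that, among these three compounds, the two longer chains stand together apart from compound 1. No supporting measurement is available to account for these numbers.

The compounds shown do not tell whether a still longer chain would keep the numbers at this level or move them, or where along the shorter chains the large change sets in. They also leave open whether a carboxylic acid in place of the hydroxycarbamoyl group would retain any of the inhibition seen with compound 2 and compound 3.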